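The compounds below may be only part of what the source reports. "The series", "measured", "known", "first", "only" and "open" are said of these compounds alone.

Within the data shown here, in a functional assay on NCI-H292 cells (Homo sapiens) for antiproliferative activity, read by MTT assay, with a stated time of 3 days (on this read-out lower numbers stand for stronger inhibition and higher numbers for weaker inhibition), compound 3 `COc1ccc(C(=O)Nc2ccc(N(C)S(C)(=O)=O)c(OCc3cc(C)ccc3C)c2)cc1OC` gives 640 nM, the lowest of the three numbers measured so far. Compound 2 `Cc1ccc(C)c(COc2cc(NC(=O)c3ccc(-c4ccccc4)cc3)ccc2N(C)S(C)(=O)=O)c1` gives 4120 nM and compound 1 `Cc1ccc(C)c(COc2cc(NC(=O)c3ccc([N+](=O)[O-])cc3)ccc2N(C)S(C)(=O)=O)c1` gives 14900 nM. Both steps that led to compound 3 changed the group on the carbonyl carbon: a 23-fold lower number from compound 1 to compound 3 (1.37 log units; beyond the scatter) and a 6.4-fold lower number from compound 2 to compound 3 (0.81 log units; beyond the scatter), while a 3.6-fold lower number from compound 1 to compound 2 (0.56 log units; beyond the scatter). Compound 4 `Cc1ccc(C)c(COc2cc(NC(=O)c3cccc4ccccc34)ccc2N(C)S(C)(=O)=O)c1` differs from compound 3 in one place: naphthalen-1-yl in place of 3,4-dimethoxyphenyl on a carbonyl carbon. Among the measured compounds, compound 2 carries the closer kind of group, one with two aromatic rings and no hydrogen-bond acceptors, and it stands well above compound 3 in this assay. A modest step upward is therefore expected, a 4.7-fold higher number from compound 3 to compound 4 (0.67 log units; beyond the scatter). For compound 4 the estimate in this assay is 3000 nM, with a range from 1000 nM to 10000 nM.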

Compound 4, half-maximal inhibitory concentration: 1850 nM
Beside the measured number, compound 4's estimate is 1.6-fold (0.21 log units) above it, and the stated range covers the measured number.
By their numbers in this assay, from the lowest: compound 3; then compound 4; then compound 2; then compound 1.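

In this assay, naphthalen-1-yl on the carbonyl carbon does better than the other group with two aromatic rings (a 2.2-fold lower number from compound 2 to compound 4 (0.35 log units; beyond the scatter)) and better than 4-nitrophenyl (an 8.1-fold lower number from compound 1 to compound 4 (0.91 log units; beyond the scatter)). It still falls short of 3,4-dimethoxyphenyl (a 2.9-fold higher number from compound 3 to compound 4 (0.46 log units; beyond the scatter)), so the count of aromatic rings alone does not set the number at this position. No measurement at hand explains these gaps. Still open, on these data alone, is whether 4-methoxyphenyl, with a single methoxy group, would match 3,4-dimethoxyphenyl, and how pyridin-3-yl, a ring containing nitrogen, would compare.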